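The compounds below may be only part of what the source reports. "The series", "measured", "known", "first", "only" and "open" are said of these compounds alone.

Compound 1 `CC(C)N(Cc1cccc(OCCCCCC(=O)O)c1)C(=O)c1ccccc1` gives > 26000 nM in an ADME assay on HepG2 cells (Homo sapiens) for cytotoxicity, read by CellTiter-Glo and resazurin assay, with a stated time of 72 h (a lower number here means that less compound is needed, a higher number that more compound is needed for the effect), a limit of the assay.
Compound 2 `CC(C)N(Cc1cccc(OCCCCCC(=O)O)c1)C(=O)c1ccc(-c2ccncc2)cc1` gives > 26000 nM in this assay, again a limit.

Both values sit at the limit of the assay, and the limit of > 26000 nM in this assay, at which 2 of the 2 values shown sit, records the same. Because of the limit of > 26000 nM in this assay, at which 2 of the 2 values shown sit, the step that the two limits leave unreadable from compound 1 to compound 2 cannot be read as a number. Compound 2 therefore stands at a limit, not at a measured value.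

Compound 3 `CC(C)N(Cc1cccc(OCCCCCC(=O)O)c1)C(=O)c1ccc(-c2cccc(-c3ccccc3)c2)cc1` carries the change (3-phenylphenyl in place of pyridin-4-yl on an aromatic carbon). Within the data shown here, only one measured step touches this part of the shared core, a step that the two limits leave unreadable from compound 1 to compound 2, and its size is unreadable between the two limits. Nothing measured here shows that a change at this place moves the read-out beyond the scatter. The expected step that the limit leaves unreadable from compound 2 to compound 3 is therefore none beyond the scatter. Compound 3 is estimated at 30000 nM, in the range 8000 nM to 100000 nM, with a fair chance that only a limit is reported again.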

Compound 3, half-maximal effective concentration: > 26000 nM
Compound 3: only a limit was reported; the forecaster's own chance of this, stated with the estimate: 65%; the middle value lies beyond the limit too.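

Compound 3 also ends at a limit, so its steps from compound 1 and from compound 2 cannot be read as numbers: the limit of > 26000 nM in this assay, at which 3 of the 3 values shown sit.

Whether any change at this place on the shared core shifts the read-out in this assay stays open, as no compound shown has a measured number.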